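Cytotoxicity notes on compounds 1 to 4

The source may report more compounds than this note shows. Statements on the series, on what has been measured and on what is new or still open speak of the compounds shown alone.

Compound 1 `O=C(c1ccccc1)c1ccc2nc(NCCC3CCCNC3)[nH]c2c1`, compound 2 `O=C(CCCC1CCNCC1)Nc1nc2ccc(C(=O)c3ccccc3)cc2[nH]1` and compound 3 `Nc1nc2ccc(C(=O)c3ccccc3)cc2n1C[C@H]1CCCN1` have been measured in an ADME assay on HL-60 cells (Homo sapiens) for cytotoxicity, read by resazurin assay, with a stated time of 72 h; on this read-out higher numbers stand for an effect only at larger amounts of compound and lower numbers for an effect already at smaller amounts. For compound 1 the result is only a limit of the assay, > 30000 nM. For compound 2 the result is likewise a limit, > 30000 nM. Compound 3 also reaches only a limit in this assay, > 30000 nM. Compound 3 thus stands where every value shown stands: the limit of > 30000 nM in this assay, at which 3 of the 3 values shown sit. Within the data shown here, no step between measured compounds is available.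

Compound 4 `CN1CCC[C@H]1CCn1c(N)nc2ccc(C(=O)c3ccccc3)cc21` has not yet been measured in this assay. It differs from compound 3 by (1-methylpyrrolidin-2-yl)methyl in place of pyrrolidin-2-yl on a saturated chain carbon bound to an aromatic nitrogen. Because every value shown sits at the limit of > 30000 nM in this assay, at which 3 of the 3 values shown sit, the step of a number no higher from compound 3 to compound 4 (the limit leaves the size open) is expected to be none beyond the scatter. Compound 4 is therefore estimated at 30000 nM, within a range of 12000 nM to 100000 nM, and most likely again only a limit in this assay.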

Compound 4, half-maximal effective concentration: > 30000 nM
Compound 4: no number, only a limit; the forecaster's own chance of this, stated with the estimate: 80%; the middle value lies on the limit itself.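

No step can be read from compound 3 to compound 4, since both results are only limits: the limit of > 30000 nM in this assay, at which 4 of the 4 values shown sit.

The compounds shown leave open at what concentration any of them would reach a half-maximal effect, and whether (1-methylpyrrolidin-2-yl)methyl in place of pyrrolidin-2-yl changes it.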